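A few compounds are considered here, and "the series" means these few. Any claim that something is new, unique, unknown or untested is made for them only; others in the source may bear on it.

Measured in an assay on isolated protein for inhibition of matrix metalloproteinase-9 (Homo sapiens), read by fluorescence, with stated times of 5 min and 30 min, tested at 5 uM; a higher number here means more inhibition at the concentration tested (going by the name of the read-out), a lower number less inhibition:

compound 1 `O=C(NO)[C@H]1C[C@@H](n2cc(-c3ccccc3)nn2)CN1S(=O)(=O)c1ccc(Cl)c(Cl)c1`: 83%
compound 2 `O=C(NO)[C@H]1C[C@@H](NS(=O)(=O)c2ccc(-c3ccccc3)cc2)CN1S(=O)(=O)c1ccc(Cl)c(Cl)c1`: 100%
compound 3 `O=C(/C=C/c1ccco1)N[C@H]1C[C@H](C(=O)NO)N(S(=O)(=O)c2ccc(Cl)c(Cl)c2)C1`: 100%

Compound 3 stands level with compound 2 within the scatter, and together the two give the highest numbers of the three. Compound 1 lies lower, and that gap to compound 3 is beyond the scatter. Among the compounds with values here, no pair of these three differs in only one place, so no single-change step is available from the measured set.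

Compound 4 `O=C(NO)[C@H]1C[C@H](OCc2ccccc2)CN1S(=O)(=O)c1ccc(Cl)c(Cl)c1` follows from compound 3 by one change: benzyloxy in place of ((2-(furan-2-yl)ethenyl)carbonyl)amino on a saturated ring carbon. The entering group is smaller than the leaving group and brings no hydrogen-bond donor, whereas the sulfonamide-bearing compound 2 gives 100% and the amide-bearing compound 3 gives 100% at this concentration; compound 1, carrying a different group at the same position, gives 83%.

For compound 4 a modest drop in this assay is expected, a step of a number 20 percentage points lower from compound 3 to compound 4 (beyond the scatter), at or just beyond the edge of the scatter. The estimate for compound 4 is 80%, with a range from 60% to 95%.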

Compound 4, a percentage reported as inhibition, at one concentration (the size of the read-out at that concentration, not a potency): 37%
The estimate for compound 4 lay 43 percentage points above the measured number; the measured number lies below the stated range.
By their numbers in this assay, from the lowest: compound 4; then compound 1; then compounds 2 and 3 (each within the scatter of the next).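

In this assay, the group on this saturated ring carbon proves able to move the read-out by a wide margin: benzyloxy in place of ((2-(furan-2-yl)ethenyl)carbonyl)amino gives a number 63 percentage points lower from compound 3 to compound 4 (beyond the scatter). Within the data shown here, this is the only single-change step available, and it shows that the shared core and the hydroxycarbamoyl group do not by themselves secure the level of compound 3 at the concentration tested. The change alters several features at once, as the amide hydrogen, the carbonyl, the ethenyl double bond and the five-membered aromatic ring all leave together, and no measurement at hand accounts for the step.

Which of these features carries the step stays open, and a benzylamino group at this position would separate the linking oxygen from the six-membered aromatic ring, while a benzoylamino group would test the amide link without the furan ring or the ethenyl unit. Also open, from the compounds shown here alone, is how a simple primary amine or a carboxylic acid at this ring carbon would read in this assay.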